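Series notes: inverted ring stereocentre, compound 4

A few compounds are considered here, and "the series" means these few. Any claim that something is new, unique, unknown or untested is made for them only; others in the source may bear on it.

Measured compounds:
compound 1 `CC[C@H]1c2cc(Cl)ccc2C(=O)N1c1cncc2c1CCC[C@H]2NC(C)=O` gives 3630 nM
compound 2 `CC(=O)N[C@@H]1CCCc2c1cncc2N1C(=O)c2ccc(Cl)cc2[C@H]1C` gives 5140 nM
compound 3 `CCC(=O)N[C@@H]1CCCc2c1cncc2N1C(=O)c2ccc(Cl)cc2[C@H]1C` gives 9410 nM

In an ADME assay on cells for inhibition of cytochrome P450 11B1, mitochondrial (Homo sapiens), read by HTRF (a higher number here means a weaker inhibitor, a lower number a stronger inhibitor), compound 2 stands second highest of the three numbers; its nearest neighbour is compound 1 and its furthest is compound 3, both within the scatter. Going by the values given here, the only single-point step measured, a 1.8-fold higher number from compound 2 to compound 3 (0.26 log units; within the scatter), is within the scatter. Compound 4 `CC(=O)N[C@@H]1CCCc2c1cncc2N1C(=O)c2ccc(Cl)cc2[C@@H]1C` differs from compound 2 by the two compounds have the same atoms and bonds and differ only in configuration as drawn: 1 of 2 stereo elements differ; a stereocentre at a saturated ring carbon is drawn R in compound 2 and S in compound 4. Among the compounds with values here, no measured step involves a change of configuration, so none bears directly on this move; the one step available concerns a chain substituent and is itself within the scatter. On these data alone, the expected step, a 1.1-fold higher number from compound 2 to compound 4 (0.03 log units; within the scatter), is therefore no change beyond the scatter, with a wide range because an inverted stereocentre is untested here. Compound 4 is estimated at 5500 nM, between 1500 nM and 20000 nM.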

Compound 4, half-maximal inhibitory concentration: 81 nM
Estimate against measurement, compound 4: 68-fold (1.83 log units) above; the measured number lies below the stated range.
By their numbers in this assay, from the lowest: compound 4; then compounds 1, 2 and 3 (each within the scatter of the next, the first and the last beyond it).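

In this assay the configuration of a stereocentre at a saturated ring carbon alone carries a 63-fold lower number from compound 2 to compound 4 (1.80 log units; beyond the scatter): the fact that compounds 2 and 4 differ only in the configuration as drawn. Hydrogen in place of methyl on a saturated chain carbon bound to a saturated ring carbon gives a 45-fold lower number from compound 1 to compound 4 (1.65 log units; beyond the scatter), so at this ring carbon the size of the substituent also counts on the configuration of compound 4, and a chain step does not read across from one core to the other: the same change on two cores in this assay, a 1.8-fold higher number (0.26 log units; within the scatter) from compound 2 to compound 3 and a 45-fold higher number (1.65 log units; beyond the scatter) from compound 4 to compound 1, 24-fold (1.39 log units) apart, beyond the scatter of two such steps. Open, on these data alone, is how the other stereocentre bears on this, and whether a longer chain, a hydroxymethyl or an amine at this ring carbon holds the level of compound 4.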